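This account rests on a few compounds, and the source may have more. Where it says the series, first, only, none or still open, it means among the compounds named here.

Measured compounds:
Compound 1 `COc1ccc(C2N=C(SCc3ccc(Cl)cc3)NC(C)=C2C(=O)Nc2ccc(F)cc2)cc1OC` gives 10.3% in a functional assay on the whole organism (artery, strain albino) with Rattus norvegicus as the target, with a stated time of 60 min, at a dose of 10 mg/kg by the oral route; on this read-out higher numbers stand for more inhibition at the one dose given (going by the name of the read-out) and lower numbers for less inhibition.
Compound 2 `COc1ccc(C2N=C(SCc3ccc(F)cc3)NC(C)=C2C(=O)Nc2ccc(F)cc2)cc1OC` gives 11.8% in this assay.
Compound 3 `CC1=C(C(=O)Nc2ccc(F)cc2)C(c2ccc([N+](=O)[O-])cc2)N=C(SCc2ccc(Cl)cc2)N1` gives 11.8% in this assay.

Compound 3 differs from compound 1 in the core: 4-nitrophenyl in place of 3,4-dimethoxyphenyl on a saturated ring carbon. Compound 2 differs from compound 1 by fluoro in place of chloro on an aromatic carbon, and that change made a step of a number 1.5 percentage points higher from compound 1 to compound 2 (within the scatter). Compound 3 stands level with compound 2 at the digits reported, the two together the highest of the three numbers, and all three lie within the scatter of one another, so no order among them is claimed.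

Compound 4 `CC1=C(C(=O)Nc2ccc(F)cc2)C(c2ccc([N+](=O)[O-])cc2)N=C(SCc2ccc(F)cc2)N1` is not yet measured. It differs from compound 3 by fluoro in place of chloro on an aromatic carbon, the same change as from compound 1 to compound 2, here made on the core of compound 3. For compound 4 a step of about a number 1.2 percentage points higher from compound 3 to compound 4 (within the scatter) is expected in this assay, beside the earlier one, because a number 1.5 percentage points higher from compound 1 to compound 2 (within the scatter) stayed within the scatter. For the measured compounds named here, this rests on that one pair only; no measured pair shows the change on the core of compound 3. Compound 4 is expected to give 13% in this assay, the range running from 4% to 22%.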

Compound 4, a percentage reported as inhibition, in the whole organism at one dose (the size of the read-out at that dose, not a potency): 10.8%
Estimate against measurement, compound 4: 2.2 percentage points above; measured number inside the range.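

In this assay, fluoro in place of chloro on the core of compound 3 gives a number 1 percentage points lower from compound 3 to compound 4 (within the scatter), and this step does not differ from the one on the core of compound 1: the same change on two cores in this assay, a number 1.5 percentage points higher (within the scatter) from compound 1 to compound 2 and a number 1 percentage points lower (within the scatter) from compound 3 to compound 4, 2.5 percentage points apart, within the scatter of two such steps

The 4-nitrophenyl in place of 3,4-dimethoxyphenyl change, read on the fluoro pair, gives a number 1 percentage points lower from compound 2 to compound 4 (within the scatter), and it likewise agrees with the step read on the chloro pair: the same change on two cores in this assay, a number 1.5 percentage points higher (within the scatter) from compound 1 to compound 3 and a number 1 percentage points lower (within the scatter) from compound 2 to compound 4, 2.5 percentage points apart, within the scatter of two such steps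

Neither change therefore shows any dependence on the core across these two cores, but with every step inside the scatter this does not show that either change has an effect in this assay, nor that a real effect would carry from one core to another.

Still open, from the compounds shown here alone, is whether any change at these places can move the read-out beyond the scatter. An amine or a carboxylic acid in place of the halogen, or a longer chain in place of the (4-fluorobenzyl)sulfanyl group, would test this on the shared core.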